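The source may hold more compounds than are shown below. What is called first, only, known or untested is meant among the compounds shown, and "the series" means these compounds.

The measured compounds are three. Compound 1 `O=C(Nc1ccc(Cl)c(-c2nnc3c(Cl)cccn23)c1)c1ccc(C(F)(F)F)cc1Cl`, compound 2 `Cc1nc(C(=O)Nc2ccc(Cl)c(-c3nnc4c(Cl)cccn34)c2)cs1` and compound 3 `O=C(Nc1ccc(Cl)c(-c2nnc3c(Cl)cccn23)c1)c1cccnc1` share one core and differ only in the group on the carbonyl carbon of the amide.

In a functional assay on MCF7 cells (Homo sapiens) for antiproliferative activity, read by MTT assay, with a stated time of 72 h (on this read-out lower numbers stand for stronger inhibition and higher numbers for weaker inhibition), compound 1 gives 81600 nM. For compound 2 this assay reports only a limit, > 100000 nM. For compound 3 it also reports only a limit, > 100000 nM. Compound 3 thus stands at the limit of > 100000 nM in this assay, at which 2 of the 3 values shown sit, and no number is known for it. Within the data shown here, the one measured step at the same position, a step that the two limits leave unreadable from compound 2 to compound 3, runs between two limits and its size cannot be read.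

The change to compound 4 `O=C(Nc1ccc(Cl)c(-c2nnc3c(Cl)cccn23)c1)c1cccc(Cl)c1` is 3-chlorophenyl in place of pyridin-3-yl on a carbonyl carbon. Compound 1, which carries another substituted ring of carbon only on the same carbonyl carbon, gives 81600 nM, a number just inside the measurable range. On that value alone, compound 4 is expected to remain very weak in this assay. The expected step of an at least 1.1-fold lower number from compound 3 to compound 4 (0.04 log units; that floor lies within the scatter) cannot be weighed against scatter, since it starts from a limit. Compound 4 is estimated at 90000 nM, between 40000 nM and 300000 nM, with a real chance that only a limit is reported.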

Compound 4, half-maximal inhibitory concentration: 71900 nM
For compound 4 the middle estimate is 1.3-fold (0.10 log units) above the measured one; measured number inside the range.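

Compound 4 gives this position a second real number: in this assay, compound 4, with 3-chlorophenyl on the carbonyl carbon, reads 71900 nM, and compound 1, which also has a ring of carbon only there, reads 81600 nM, and no order can be drawn between these two values. The steps that reach compound 4, an at least 1.3-fold lower number from compound 3 to compound 4 (0.14 log units; that floor lies within the scatter) and an at least 1.3-fold lower number from compound 2 to compound 4 (0.14 log units; that floor lies within the scatter), both start from a limit, so they give only a floor and their full size cannot be read. Among the four compounds, the two with a ring of carbon only on this carbonyl carbon give numbers, whereas compound 2 and compound 3, whose rings hold hetero atoms, stay at a limit of the assay: the limit of > 100000 nM in this assay, at which 2 of the 4 values shown sit.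

Whether the true numbers of compound 2 and compound 3 lie far from that of compound 4 stays unknown, and the compounds shown do not tell whether the chlorine or the ring of carbon itself carries the difference. Also open, going by these compounds, is how an unsubstituted phenyl, a piperidine or a carboxylic acid on the same carbonyl carbon would read in this assay.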